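This account rests on a few compounds, and the source may have more. Where it says the series, first, only, none or still open, it means among the compounds named here.

Measured so far:
Compound 1, `CCN(CC)c1cc(C)nc(N(CC)c2ccc(C(C)=O)cc2Br)n1`: in an assay on isolated protein for binding affinity to corticotropin-releasing factor receptor 1 (Homo sapiens) (a higher number here means a weaker inhibitor, a lower number a stronger inhibitor), compound 1 gives 5 nM.
Compound 2, `CCCCN(CC)c1cc(C)nc(N(CC)c2ccc(I)cc2Br)n1`: in this assay compound 2 gives 14 nM.

Of the two measured compounds, compound 2 stands at the higher number, and so is the weaker binder of the pair; its nearest neighbour is compound 1, whose number is lower by a gap that lies beyond the usual scatter of this assay. The two compounds differ in more than one place, so the numbers alone do not say which part of the structure accounts for the gap.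

Compound 3, `CCN(CC)c1cc(C)nc(N(CC)c2ccc(I)cc2Br)n1`, is built from compound 2 by a single change: hydrogen in place of ethyl on a saturated chain carbon, two bonds along the chain from a nitrogen on an aromatic ring. Among the compounds with values here, no pair of measured compounds shows this change in isolation, so there is no measured step to lean on. Compound 1 carries the same diethylamino group that compound 3 will carry, and compound 1 sits at the lower number, but its other group also differs, so it gives only a loose hint. For compound 3 the expected step is a 1.8-fold lower number from compound 2 to compound 3 (0.24 log units; within the scatter), a modest move towards a lower number. Compound 3 is estimated at 8 nM, with a range from 3 nM to 25 nM.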

Compound 3, inhibition constant: 9 nM
Compound 3: the middle estimate sits 1.1-fold (0.05 log units) below what was measured; the measured number falls inside the stated range.
By their numbers in this assay, from the lowest: compounds 1, 3 and 2 (each within the scatter of the next, the first and the last beyond it).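

The swap of hydrogen for ethyl at this chain carbon, which turns butyl(ethyl)amino into diethylamino, gives a 1.6-fold lower number from compound 2 to compound 3 (0.19 log units; within the scatter) in this assay and lies within the scatter, so butyl and ethyl cannot be told apart at this position. Iodo in place of acetyl on the aromatic carbon gives a 1.8-fold higher number from compound 1 to compound 3 (0.26 log units; within the scatter) and also lies within the scatter, which means that the gap between compound 1 and compound 2, two compounds that differ in two places, now divides into two single changes, neither beyond the scatter by itself. No measurement shown here offers an explanation for these numbers.

The compounds shown leave open how far this chain can change in either direction, for example whether a longer chain such as hexyl, or a hydroxyl at the chain end, would keep the number in the same range. They also leave open whether the aromatic carbon that carries iodo or acetyl would accept a different kind of group, such as an amine or a carboxylic acid.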